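A few compounds are considered here, and "the series" means these few. Any claim that something is new, unique, unknown or untested is made for them only; others in the source may bear on it.

Compound 1 `C[C@@H]1CN(c2sc(C(F)(F)F)nc2-c2nc3cc(OCCO)ccc3[nH]2)CCN1C(=O)Cn1cnc2cccnc21` was examined in an ADME assay on microsomes from liver (Homo sapiens) for metabolic stability, read by LC-MS, using NADPH, with a stated time of 15 min, tested at 1 uM (on this read-out higher numbers stand for fast clearance and lower numbers for slow clearance), where compound 1 gives 43 mL.min-1.g-1. Among the compounds with values here, compound 2 `Cc1nc(C)n(CC(=O)N2CCN(c3sc(C(F)(F)F)nc3-c3nc4cccc(C)c4[nH]3)C[C@H]2C)n1` is the only other compound measured alongside it, and in this assay compound 2 gives 100 mL.min-1.g-1, which puts compound 1 at the lower of the two numbers, with compound 2 lying beyond the usual scatter above it. Within the data shown here, no pair of measured compounds differing in a single place is available, so the effect of any one change has to be judged from these two numbers and from the structures themselves.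

Compound 3 `C[C@@H]1CN(c2sc(C(F)(F)F)nc2-c2nc3ccccc3[nH]2)CCN1C(=O)Cn1cnc2cccnc21` is a close relative of compound 1. The change is hydrogen in place of 2-hydroxyethoxy on an aromatic carbon. Among the measured compounds shown here, since compound 2, the only comparison at hand, gives 100 mL.min-1.g-1, and compound 3 loses a group that compound 1 carries, the expectation is a modest rise, with the estimated step of a 1.5-fold higher number from compound 1 to compound 3 (0.18 log units; within the scatter) from compound 1 to compound 3 going in the direction of faster clearance. On that basis compound 3 is estimated to give 65 mL.min-1.g-1 in this assay, with an expected range from 30 mL.min-1.g-1 to 130 mL.min-1.g-1.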

Compound 3, intrinsic clearance in microsomes in the Homo sapiens assay: 89 mL.min-1.g-1
The estimate for compound 3 lay 1.4-fold (0.14 log units) below the measured number; measured number inside the range.
By their numbers in the Homo sapiens assay, from the lowest: compound 1; then compounds 3 and 2 (each within the scatter of the next).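

Within the data shown here, replacing the 2-hydroxyethoxy group with hydrogen on this aromatic carbon gives the first comparison in which only one place differs, and in the Homo sapiens assay the change is a 2.1-fold higher number from compound 1 to compound 3 (0.32 log units; beyond the scatter). In a physicochemical assay for lipophilicity, at pH 7.4 (on this read-out higher numbers stand for higher lipophilicity and lower numbers for lower lipophilicity), compound 1 gives 2.4 and compound 3 gives 3.9, so the same change also produces a large shift in the distribution coefficient. Faster clearance therefore accompanies higher lipophilicity in this pair, and with the physicochemical assay as the only other measured property, lipophilicity is the one measured difference that could account for the rise: the measured distribution coefficient of compound 1, 2.4, and of compound 3, 3.9, a number 1.50 log units higher (beyond the scatter)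

The compounds shown leave open whether a methoxy group, a hydroxyl group or a longer chain ending in an amine on this aromatic carbon would give clearance nearer to that of compound 1 or of compound 3, and so whether the whole 2-hydroxyethoxy group is needed. They also leave open whether clearance and the distribution coefficient move together at other places on the shared core, as this single pair speaks only for this position and this change.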